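The compounds below may be only part of what the source reports. "The series", "measured", "known", "first", "only" and "open" are said of these compounds alone.

Measured in a functional assay on NIH3T3 cells (Mus musculus) for inhibition, read by MTT assay, with a stated time of 72 h; on this read-out higher numbers stand for weaker inhibition and lower numbers for stronger inhibition:
- compound 1 `C=C1CC[C@H]2[C@@](C)(CC[C@@H](OC(C)=O)[C@@]2(C)C(=O)OCc2ccccn2)[C@@H]1CCC1=CCOC1=O` gives 55500 nM
- compound 2 `C=C1CC[C@H]2[C@@](C)(CC[C@@H](OC(C)=O)[C@@]2(C)C(=O)OC)[C@@H]1/C=C/C1=CCOC1=O` gives 32300 nM
- compound 3 `C=C1CC[C@H]2[C@@](C)(CC[C@@H](OC(C)=O)[C@@]2(C)C(=O)OCc2ccccc2)[C@@H]1/C=C/C1=CCOC1=O` gives 52700 nM

These three values all lie within the usual scatter of one another, so compound 3 stands level with both neighbours and no ranking can be drawn from them. Compound 4 `C=C1CC[C@H]2[C@@](C)(CC[C@@H](OC(C)=O)[C@@]2(C)C(=O)OCc2ccccn2)[C@@H]1/C=C/C1=CCOC1=O` has not been measured yet. It differs from compound 3 by pyridin-2-yl in place of phenyl on a saturated chain carbon bound to an oxygen next to a carbonyl group and in words it has pyridin-2-yl in place of phenyl on a saturated chain carbon bound to an oxygen next to a carbonyl group.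

For the measured compounds named here, the one measured step at this place is a 1.6-fold higher number from compound 2 to compound 3 (0.21 log units; within the scatter) and it shows little response there. Compound 1 already carries pyridin-2-yl, though with a different chain, and compound 1 at 55500 nM also stays level with the others. The expected step is therefore a 1.1-fold lower number from compound 3 to compound 4 (0.06 log units; within the scatter) and nothing beyond the scatter is expected in this assay here. For compound 4 the estimated value is 46000 nM with an expected range from 24000 nM to 88000 nM as the likely span.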

Compound 4, half-maximal inhibitory concentration: 34900 nM
Compound 4: the middle estimate sits 1.3-fold (0.12 log units) above what was measured; the range from low to high includes it.
By their numbers in this assay, from the lowest: compounds 2, 4, 3 and 1 (each within the scatter of the next).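

In this assay, pyridin-2-yl in place of phenyl gives a 1.5-fold lower number from compound 3 to compound 4 (0.18 log units; within the scatter) and so the ring nitrogen, with its one hydrogen-bond acceptor, does not set the two compounds apart at this saturated chain carbon bound to an oxygen next to a carbonyl group. The pyridin-2-yl group also leaves compound 4 level with the methyl ester, with a 1.1-fold higher number from compound 2 to compound 4 (0.03 log units; within the scatter) and this adds a second aromatic group to the phenyl step, neither moving the number beyond the scatter. A change in the other place, the group on a saturated ring carbon, gives a 1.6-fold lower number from compound 1 to compound 4 (0.20 log units; within the scatter) and is equally small, while nothing available explains this flat picture.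

Going by these compounds, whether any group at the ester position can move the number beyond the scatter stays open. A carboxylic acid or an amine-bearing chain there would put that to the test.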